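Swapping Phenyl for Diethylamino on a Shared Core

The source may report more compounds than this note shows. Statements on the series, on what has been measured and on what is new or still open speak of the compounds shown alone.

Measured in a functional assay on HepG2 cells (Homo sapiens) for antiproliferative activity, read by MTT assay, with a stated time of 48 h; on this read-out higher numbers stand for weaker inhibition and lower numbers for stronger inhibition:
- compound 1 `CCCCOc1ccc(C(=O)/C=C/c2c(/C=C/c3ccc(OC)cc3)cc(OC)cc2OC)cc1`: 12.9 ug/mL
- compound 2 `CCCCCCOc1ccc(C(=O)/C=C/c2c(/C=C/c3ccc(OC)cc3)cc(OC)cc2OC)cc1`: 16.2 ug/mL
- compound 3 `COc1ccc(/C=C/c2cc(OC)cc(OC)c2/C=C/C(=O)c2ccc(-c3ccccc3)cc2)cc1`: 10.5 ug/mL

In this assay compound 3 gives 10.5 ug/mL, and it stands level with the other two compounds. Its nearest neighbour is reached by a 1.2-fold lower number from compound 1 to compound 3 (0.09 log units; within the scatter), and its furthest by a 1.5-fold lower number from compound 2 to compound 3 (0.19 log units; within the scatter). Both steps lie within the scatter.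

The next compound is compound 4 `CCN(CC)c1ccc(C(=O)/C=C/c2c(/C=C/c3ccc(OC)cc3)cc(OC)cc2OC)cc1`, where diethylamino stands in place of phenyl on an aromatic carbon, para to a large group: diethylamino in place of phenyl on an aromatic carbon.

Among the compounds with values here, no measured compound carries diethylamino, so the evidence is indirect. The two steps above bear most closely on this change, since each exchanges the group at this same place, and neither exceeds the scatter. The chain extension, a 1.3-fold higher number from compound 1 to compound 2 (0.10 log units; within the scatter), is also within the scatter. Across butoxy, hexyloxy and phenyl, then, the measured values show no separation. On these data alone, on that basis, no change beyond the scatter is expected in this assay, though a nitrogen-linked group is untested here and the range is kept wide. The expected step is a 1.1-fold higher number from compound 3 to compound 4 (0.06 log units; within the scatter). For compound 4 the estimated value is 12 ug/mL, with an expected range from 5.5 ug/mL to 26 ug/mL.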

Compound 4, half-maximal inhibitory concentration: 6.3 ug/mL
Compound 4: middle estimate off by 1.9-fold (0.28 log units), on the high side; measured number inside the range.
By their numbers in this assay, from the lowest: compounds 4, 3, 1 and 2 (each within the scatter of the next, the first and the last beyond it).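

In this assay, within the data shown here, this position now shows a separation that butoxy, hexyloxy and phenyl did not show among themselves: diethylamino, the only nitrogen-linked group among the four compounds, gives a 2.0-fold lower number from compound 1 to compound 4 (0.31 log units; beyond the scatter) and a 2.6-fold lower number from compound 2 to compound 4 (0.41 log units; beyond the scatter) as modest steps, both beyond the scatter. Against phenyl, however, the same group gives a 1.7-fold lower number from compound 3 to compound 4 (0.22 log units; within the scatter) and stays within the scatter, so compound 3 goes against any claim that diethylamino stands apart from every other group at this place, and the separation holds only against the two ether chains. Why the nitrogen-linked group differs from butoxy and hexyloxy cannot be said, as no supporting data bear on the cause.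

The compounds shown leave open whether the step belongs to diethylamino alone or extends to other amines at this aromatic carbon, such as dimethylamino, pyrrolidine, piperidine or morpholine. They also leave open whether a shorter ether such as methoxy, or an unsubstituted phenyl ketone with hydrogen at this place, would fall with the ether chains or with compound 4.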